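The compounds below may be only part of what the source reports. "The series", "measured", "known", "first", "only" and "open" are said of these compounds alone.

Measured compounds:
compound 1, `O=C(NCC(=O)N1[C@@H](c2ccccc2)CC[C@H]1C(=O)O)[C@@H](S)Cc1ccc(O)cc1`, gives 3.4 nM in an assay on isolated protein for inhibition of Neprilysin (Oryctolagus cuniculus); a lower number here means a stronger inhibitor, a higher number a weaker inhibitor.
compound 2, `O=C(NCC(=O)N1[C@@H](c2cccc(O)c2)CC[C@H]1C(=O)O)[C@@H](S)Cc1ccccc1`, gives 2.4 nM in this assay.
compound 3, `O=C(NCC(=O)N1[C@@H](c2ccccc2O)CC[C@H]1C(=O)O)[C@@H](S)Cc1ccc(O)cc1`, gives 3.5 nM in this assay.

Compound 3 is not set apart from its two neighbours: the step of a 1.0-fold higher number from compound 1 to compound 3 (0.01 log units; within the scatter) lies within the scatter, and the gap between compound 3 and compound 2 is also within the scatter, so the three measured compounds cannot be told apart in this assay.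

Compound 4, `O=C(NCC(=O)N1[C@@H](c2cccc(O)c2)CC[C@H]1C(=O)O)[C@@H](S)Cc1ccc(O)cc1`, has not yet been measured. It differs from compound 3 by 3-hydroxyphenyl in place of 2-hydroxyphenyl on a saturated ring carbon. Among the measured compounds shown here, no measured step moves a hydroxy group around the ring on the saturated ring carbon, so the change itself has no direct precedent. For the measured compounds named here, the one step that touches that ring, a 1.0-fold higher number from compound 1 to compound 3 (0.01 log units; within the scatter), shows that putting a hydroxy group there changed nothing beyond the scatter, and compound 2, which already carries the 3-hydroxyphenyl group, sits within the scatter of compound 1 and compound 3. The expected step of a 1.2-fold lower number from compound 3 to compound 4 (0.07 log units; within the scatter) is therefore none beyond the scatter. Compound 4 is estimated at 3 nM in this assay, with a range from 1.5 nM to 6 nM.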

Compound 4, half-maximal inhibitory concentration: 1.6 nM
For compound 4 the middle estimate is 1.9-fold (0.27 log units) above the measured one; measured number inside the range.
By their numbers in this assay, from the lowest: compounds 4, 2, 1 and 3 (each within the scatter of the next, the first and the last beyond it).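

In this assay, among the compounds shown here, moving the hydroxy group from 2-hydroxyphenyl to 3-hydroxyphenyl on the saturated ring carbon gives a 2.2-fold lower number from compound 3 to compound 4 (0.34 log units; beyond the scatter), the first modest step beyond the scatter at this position, so there the place of the hydroxy group on the phenyl ring can be told apart in this assay. The same reading comes from the core of compound 1, where 3-hydroxyphenyl in place of phenyl gives a 2.1-fold lower number from compound 1 to compound 4 (0.33 log units; beyond the scatter), while 2-hydroxyphenyl in place of phenyl had left the number within the scatter. A hydroxy group in place of hydrogen on an aromatic carbon does not by itself move the number, as a 1.5-fold lower number from compound 2 to compound 4 (0.18 log units; within the scatter) also stays within the scatter, and the two such steps agree with each other: the same change on two cores in this assay, a 1.0-fold higher number (0.01 log units; within the scatter) from compound 1 to compound 3 and a 1.5-fold lower number (0.18 log units; within the scatter) from compound 2 to compound 4, 1.5-fold (0.19 log units) apart, within the scatter of two such steps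

Going by these compounds, only hydrogen and hydroxy are compared on this phenyl ring, so it stays open whether an amine, a methoxy group or a carboxylic acid in the place of the hydroxy group would keep or lose the number of compound 4. On these data alone, it also stays open whether the step from 2-hydroxyphenyl to 3-hydroxyphenyl repeats on the core of compound 2.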